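The source may hold more compounds than are shown below. What is called first, only, known or untested is meant among the compounds shown, and "the series" means these compounds.

Working notes on the series. The shared core of compound 1 `CC(C)n1ncc2c(C(=O)NC3CCCC3)cccc21` carries an amide-type nitrogen bearing cyclopentyl. In a functional assay on HepG2 cells (Homo sapiens) for inhibition, read by MTT assay, with a stated time of 72 h (on this read-out higher numbers stand for weaker inhibition and lower numbers for stronger inhibition), compound 1 gives > 40000 nM, which is a limit of the assay and not a number. Compound 2 `CC(C)n1ncc2c(C(=O)NCc3ccccc3)cccc21` has benzyl in place of cyclopentyl on that nitrogen. In this assay compound 2 gives > 40000 nM, again a limit. The step that the two limits leave unreadable from compound 1 to compound 2 is therefore unreadable. Compound 3 `Cc1ccc(-n2cc(CNC(=O)c3cccc4c3cnn4C(C)C)nn2)cc1C` extends the benzyl position into a five-membered aromatic ring with 3 nitrogen bearing 3,4-dimethylphenyl. In this assay compound 3 gives > 40000 nM, also a limit. Within the data shown here, compound 3 thus stands at the limit of > 40000 nM in this assay, at which 3 of the 3 values shown sit, and no measured step in this set has a readable size.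

Compound 4 `CC(C)n1ncc2c(C(=O)NCc3cn(-c4ccc(F)cc4)nn3)cccc21` differs from compound 3 by 4-fluorophenyl in place of 3,4-dimethylphenyl on an aromatic nitrogen. Among the measured compounds shown here, no measured step bears on this change, and the only step recorded between compounds 1 and 2 is of unreadable size. The expected value for compound 4 in this assay is therefore set close to the limit of compound 3, with the step that the limit leaves unreadable from compound 3 to compound 4 expected to be none beyond the scatter. Compound 4 is estimated at 60000 nM, with a range from 20000 nM to 200000 nM, and a limit rather than a number is the more probable outcome.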

Compound 4, half-maximal inhibitory concentration: > 40000 nM
Compound 4 ended at the assay's limit; the forecaster's own chance of this, stated with the estimate: 80%; the middle value does not contradict the limit.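

Among these compounds, compound 3 and compound 4 both give a limit of the assay and not a number, so no step between them can be read: the limit of > 40000 nM in this assay, at which 4 of the 4 values shown sit.

The compounds shown leave open whether any group on the amide-type nitrogen or on the aromatic nitrogen gives a number rather than a limit in this assay.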